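The compounds below may be only part of what the source reports. "The series", "measured", "known", "first", "only" and "open" are said of these compounds alone.

Values measured in a functional assay on HT-29 cells (Homo sapiens) for inhibition, read by MTT assay, with a stated time of 3 days; a lower number here means a stronger inhibitor, a higher number a weaker inhibitor:

- Compound 1 `C=CCOc1cc(/C=C\c2cc(OC)c(OC)c(OC)c2)ccc1OC` gives 29000 nM
- Compound 2 `COCOc1ccccc1/C=C/CCCOc1cc(/C=C\c2cc(OC)c(OC)c(OC)c2)ccc1OC` gives 9600 nM
- Compound 3 `COCOc1ccc(/C=C/CCCOc2cc(/C=C\c3cc(OC)c(OC)c(OC)c3)ccc2OC)cc1` gives 7000 nM

Compound 3 has the lowest number of the three, but compound 2 lies within the scatter of it. Only compound 1 stands clearly apart, with a higher number.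

The next compound, compound 4 `COc1ccc(/C=C\c2cc(OC)c(OC)c(OC)c2)cc1OCCC/C=C/c1ccc(Cl)cc1`, differs from compound 3 in one place: chloro in place of methoxymethoxy on an aromatic carbon.

Within the data shown here, no measured compound carries chloro, so the data offer no direct guide to this exchange. The nearest evidence is a 1.4-fold lower number from compound 2 to compound 3 (0.14 log units; within the scatter), a change from 2-(methoxymethoxy)phenyl to 4-(methoxymethoxy)phenyl that stays within the scatter. On that slim basis, the estimated step is a 1.2-fold lower number from compound 3 to compound 4 (0.07 log units; within the scatter), and no change beyond the scatter is expected in this assay.

For compound 4 the estimated value is 6000 nM, with an expected range from 2000 nM to 18000 nM.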

Compound 4, half-maximal inhibitory concentration: 18000 nM
Beside the measured number, compound 4's estimate is 3.0-fold (0.48 log units) below it, and the stated range covers the measured number.
By their numbers in this assay, from the lowest: compounds 3, 2, 4 and 1 (each within the scatter of the next, the first and the last beyond it).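

In this assay, putting chloro in place of methoxymethoxy on this aromatic carbon, para to a large group, gives a 2.6-fold higher number from compound 3 to compound 4 (0.41 log units; beyond the scatter) as a modest step beyond the scatter. The earlier pair, with a 1.4-fold lower number from compound 2 to compound 3 (0.14 log units; within the scatter) inside the scatter, gave no such sign that the number responds to what sits on this ring. The two other comparisons stay within the scatter, with a 1.9-fold higher number from compound 2 to compound 4 (0.27 log units; within the scatter) for the exchange of 2-(methoxymethoxy)phenyl for 4-chlorophenyl and a 1.6-fold lower number from compound 1 to compound 4 (0.21 log units; within the scatter) for the exchange of vinyl for 4-(4-chlorophenyl)but-3-en-1-yl, so neither pair can be told apart here.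

Nothing available gives a reason for the step from methoxymethoxy to chloro. Going by these compounds, whether fluoro, an amine or a carboxylic acid on this same aromatic carbon would give a lower or a higher number remains open.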